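The compounds below may be only part of what the source reports. "The series", "measured", "known", "first", "only" and "open" are said of these compounds alone.

The measured compounds:
compound 1, `CC(C)N1CC[C@H](NC(=O)c2cc(-c3ccc(NS(=O)(=O)c4cccc(Cl)c4Cl)cc3)nc3[nH]ncc23)C1`, an assay for inhibition of serine/threonine-protein kinase Sgk1 (Homo sapiens), with stated times of 30 min and 60 min, in the presence of a further agent that is not named here; on this read-out higher numbers stand for weaker inhibition and lower numbers for stronger inhibition: 4 nM
compound 2, `CCOc1nc(-c2ccc(NS(=O)(=O)c3cc(Cl)ccc3F)cc2)nc2[nH]nc(C)c12`, this assay: 23 nM

For the measured compounds named here, of the two numbers so far, compound 2 stands highest; its nearest neighbour, compound 1, gives the lower number, and the gap between them lies beyond the usual scatter. Going by the values given here, the two differ in several places at once, so no single step between them is on record, and their values can only be set side by side. Compound 3, `Cc1n[nH]c2nc(-c3ccc(NS(=O)(=O)c4cc(Cl)ccc4F)cc3)nc(OC3CC(C)(C)N(C)C(C)(C)C3)c12`, has not yet been measured in this assay. It differs from compound 2 in one place: 1,2,2,6,6-pentamethylpiperidin-4-yl in place of ethyl on an oxygen on an aromatic ring. Among the compounds with values here, no measured pair shows this change, so the expectation rests on the two values above alone. The step is expected to be a 2.9-fold lower number from compound 2 to compound 3 (0.46 log units; beyond the scatter), toward stronger inhibition and somewhat beyond the scatter. Compound 3 is estimated at 8 nM, with a range from 2 nM to 30 nM.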

Compound 3, half-maximal inhibitory concentration: 2 nM
Compound 3: the middle estimate sits 4.0-fold (0.60 log units) above what was measured, and the stated range covers the measured number.
By their numbers in this assay, from the lowest: compounds 3 and 1 (each within the scatter of the next); then compound 2.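

The oxygen on the aromatic ring of the shared core accepts far more than an ethyl group: in this assay, placing 1,2,2,6,6-pentamethylpiperidin-4-yl there gives a 12-fold lower number from compound 2 to compound 3 (1.06 log units; beyond the scatter) and this large step runs toward stronger inhibition. The earlier compounds shown here could not show this, since compound 1 and compound 2 differ in several places at once and offered no single step at this position. Nothing at hand explains the size of this step.

The compounds shown leave open whether the gain follows the ring itself, its nitrogen or its methyl groups. From the compounds shown here alone, a plain cyclohexyl or an unmethylated piperidin-4-yl on the same oxygen would begin to separate these, and it also remains open whether an open-chain amine would serve as well.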